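The source may report more compounds than this note shows. Statements on the series, on what has been measured and on what is new or still open speak of the compounds shown alone.

In a functional assay on aorta (Rattus norvegicus) for inhibition (on this read-out lower numbers stand for stronger inhibition and higher numbers for weaker inhibition), compound 1 (`O=C(Nc1cc2cc[nH]c(=O)c2cc1Cl)C1CNCC1c1ccc(Cl)cc1Cl`) has the entry "not determined" (no result reported), so it has no number from which to measure a step. Among the compounds with values here, the only measured neighbour is compound 2 (`CN1CCC(C(=O)Nc2cc3cc[nH]c(=O)c3cc2Cl)CC1`), which shares the chlorinated bicyclic amide portion of compound 1 but carries a different amide partner. Compound 2 gives 250 nM. Compound 3 (`O=C(Nc1cc2cc[nH]c(=O)c2cc1Cl)C1CNCC1c1ccccc1`) keeps the core of compound 1 and has phenyl in place of 2,4-dichlorophenyl on a saturated ring carbon. Within the data shown here, no measured pair shows what this change does in this assay, so any step is a tentative expectation. A moderate move towards weaker inhibition is expected relative to compound 1, but its size cannot be anchored to a value for that compound. Compound 3 is estimated at 300 nM, with an expected range of 60 nM to 1500 nM.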

Compound 3, half-maximal inhibitory concentration: 89 nM
For compound 3 the middle estimate is 3.4-fold (0.53 log units) above the measured one; measured number inside the range.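

No step can be read from compound 1 to compound 3 in this assay, where compound 1 has the entry "not determined" (no result reported). The compounds shown leave open what phenyl in place of 2,4-dichlorophenyl does to inhibition. No further evidence bears on this result.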